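The source may hold more compounds than are shown below. What is called first, only, known or untested is meant among the compounds shown, and "the series" means these compounds.

The study centres on compound 1 `CC1=CC[C@@H]([C@@](C)(O)CCCC(C)(C)NC(=S)N/N=C\c2ccccc2)CC1`, whose core is kept throughout while the aromatic ring at the far end of the side chain is varied. In a functional assay on MCF7 cells (Homo sapiens) for cytotoxicity, read by sulforhodamine B assay (a lower number here means a stronger inhibitor of growth, a higher number a weaker inhibitor of growth), compound 1 gives 28700 nM, the lowest of the two numbers recorded so far. Compound 2 `COc1ccc(/C=N\NC(=S)NC(C)(C)CCC[C@](C)(O)[C@@H]2CC=C(C)CC2)cc1`, which carries methoxy in place of hydrogen on an aromatic carbon, gives 94900 nM in this assay, and the step of a 3.3-fold higher number from compound 1 to compound 2 (0.52 log units; beyond the scatter). Compound 3 `CC1=CC[C@@H]([C@@](C)(O)CCCC(C)(C)NC(=S)N/N=C\c2ccccc2[N+](=O)[O-])CC1`, with nitro in place of hydrogen on an aromatic carbon, reached only (the limit of > 100000 nM in this assay, at which 1 of the 3 values shown sits), so its value is a limit and not a number. In this assay compound 3 is recorded as > 100000 nM. The step of an at least 3.4-fold higher number from compound 1 to compound 3 (0.54 log units; beyond the scatter), while the comparison an at least 1.0-fold higher number from compound 2 to compound 3 (0.02 log units; that floor lies within the scatter).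

Compound 4 `CC1=CC[C@@H]([C@@](C)(O)CCCC(C)(C)NC(=S)N/N=C\c2cccc([N+](=O)[O-])c2)CC1` has not yet been measured in this assay. It differs from compound 1 by nitro in place of hydrogen on an aromatic carbon. Both measured additions to that aromatic ring raised the number modestly, the nitro case at least so, and a rise of similar size is therefore expected here, with the step of a 2.8-fold higher number from compound 1 to compound 4 (0.45 log units; beyond the scatter). Compound 4 is estimated at 80000 nM in this assay, with a range from 35000 nM to 200000 nM.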

Compound 4, concentration for total growth inhibition: 18300 nM
The estimate for compound 4 lay 4.4-fold (0.64 log units) above the measured number, and the stated range ends above it.
By their numbers in this assay, from the lowest: compounds 4 and 1 (each within the scatter of the next); then compound 2. At a limit, above all of these: compound 3.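

Nitro on this aromatic ring does not by itself raise the number in this assay, as the earlier compounds had suggested: placed meta to a large group it leaves the reading level with that of the unsubstituted phenyl, with a 1.6-fold lower number from compound 1 to compound 4 (0.20 log units; within the scatter). Where the nitro sits therefore matters among the compounds shown, since 3-nitrophenyl stands well clear of 2-nitrophenyl, with an at least 5.4-fold lower number from compound 3 to compound 4 (0.73 log units; beyond the scatter), and also of 4-methoxyphenyl, with a 5.2-fold lower number from compound 2 to compound 4 (0.71 log units; beyond the scatter). The reading for compound 3 is a limit and not a number, so the first of these steps gives only a floor for the gap: the limit of > 100000 nM in this assay, at which 1 of the 4 values shown sits.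

From the compounds shown here alone, whether methoxy meta to a large group would also stay level with compound 1, and whether an amine or a carboxylic acid at that place would do the same as nitro, remains open. The values show that the place of the nitro goes with the reading, but they give no reason for it, and they rest on a single nitro pair, so no wider rule about this ring can be drawn from them.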